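Replacing the benzyl group of compound 1 with 4-ethylbenzyl

The compounds below may be only part of what the source reports. "The series", "measured", "known", "first", "only" and "open" are said of these compounds alone.

In a functional assay on A2780 cells (Homo sapiens) for antiproliferative activity, read by resazurin assay, with a stated time of 72 h (on this read-out higher numbers stand for weaker inhibition and lower numbers for stronger inhibition), compound 1 `CN(Cc1ccccc1)C(=O)c1cc2c(Cc3cccc(F)c3)n[nH]c2cc1O` gives 1700 nM, the highest of the three numbers in hand. Compound 3 `Cc1cccc(Cc2n[nH]c3cc(O)c(C(=O)N(C)Cc4cccc(F)c4)cc23)c1` reads 440 nM and compound 2 `CN(Cc1ccccc1Br)C(=O)c1cc2c(Cc3cccc(Cl)c3)n[nH]c2cc1O` reads 130 nM, both lower beyond the scatter. Compound 4 `CCc1ccc(Cc2n[nH]c3cc(O)c(C(=O)N(C)Cc4ccccc4)cc23)cc1` has 4-ethylphenyl in place of 3-fluorophenyl on a saturated chain carbon bound to an aromatic carbon. Among the compounds with values here, no measured pair differs in one place only, so the size of this step in this assay remains unshown. A modest move to a lower number is expected, because compound 1 at 1700 nM stands at the top of the series. The expected step is a 2.4-fold lower number from compound 1 to compound 4 (0.39 log units; beyond the scatter). Compound 4 is estimated at 700 nM, with an expected range of 150 nM to 2500 nM.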

Compound 4, half-maximal inhibitory concentration: > 10000 nM
Compound 4: only a limit was reported; the forecaster's own chance of this, stated with the estimate: 2%; middle value at least 14-fold (1.15 log units) away from the limit.
By their numbers in this assay, from the lowest: compound 2; then compound 3; then compound 1. At a limit, above all of these: compound 4.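

In this assay compound 4 reads > 10000 nM, which is a limit of the assay and not a number. This gives the series its first change in one place: 3-fluorobenzyl to 4-ethylbenzyl is an at least 5.8-fold higher number from compound 1 to compound 4 (0.76 log units; beyond the scatter). The group on this saturated chain carbon therefore matters to the read-out, and this change moves it towards weaker inhibition, by a size known only as a bound.

As far as these compounds go, whether the step belongs to the entering ethyl group, the leaving fluorine or both stays open. Also open, from the compounds shown here alone, is how a methyl group, an amine or a carboxylic acid in place of that ethyl group would read.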